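Phenyl in Place of Methyl: Expected Cytotoxicity of Compound 4

The compounds below may be only part of what the source reports. "The series", "measured", "known", "first", "only" and "open" are said of these compounds alone.

Of the compounds shown here, three have been measured in an ADME assay on Vero cells (Chlorocebus sabaeus) for cytotoxicity, read by MTT assay, with a stated time of 72 h; on this read-out lower numbers stand for higher toxicity in this test and higher numbers for lower toxicity in this test. Compound 1 `Cc1nnc(C2(O)CC(C)CC(C)(C)C2)[nH]1` gives 380 ug/mL, compound 3 `CC1CC(C)(C)CC(O)(c2nnc(-c3ccccc3)[nH]2)C1` gives 383 ug/mL, and compound 2 `Cc1nnc(C(O)C2CC=CCC2)[nH]1` gives 318 ug/mL; all three numbers lie within the scatter of one another. Compound 3 arises from compound 1 by a single change, (phenyl in place of methyl on an aromatic carbon), and that change made a 1.0-fold higher number from compound 1 to compound 3 (0.00 log units; within the scatter). Compound 4 `OC(c1nnc(-c2ccccc2)[nH]1)C1CC=CCC1` has not yet been measured; it arises from compound 2 by phenyl in place of methyl on an aromatic carbon. The difference between the core of compound 2 and the core of compound 1 is not broken down here. The two changes are the same kind of change, not the same: around the place, compound 1 has "two ring bonds from the ring atom that bears a large group", whereas compound 2 has "two ring bonds from the ring atom that bears a group of 8 heavy atoms". In this assay the expected step is a 1.0-fold higher number from compound 2 to compound 4 (0.00 log units; within the scatter), beside the earlier 1.0-fold higher number from compound 1 to compound 3 (0.00 log units; within the scatter), because a 1.0-fold higher number from compound 1 to compound 3 (0.00 log units; within the scatter) stayed within the scatter. Compound 4 is therefore estimated at 320 ug/mL, between 190 ug/mL and 540 ug/mL.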

Compound 4, half-maximal cytotoxic concentration: 358 ug/mL
Beside the measured number, compound 4's estimate is 1.1-fold (0.05 log units) below it; low and high end bracket the measured number.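

In this assay, phenyl in place of methyl on an aromatic carbon gave a 1.1-fold higher number from compound 2 to compound 4 (0.05 log units; within the scatter), so this step also stayed within the scatter. Set beside the earlier step, the change carried from one core to the other without a difference that could be read: the same change on two cores in this assay, a 1.0-fold higher number (0.00 log units; within the scatter) from compound 1 to compound 3 and a 1.1-fold higher number (0.05 log units; within the scatter) from compound 2 to compound 4, 1.1-fold (0.05 log units) apart, within the scatter of two such steps. This shows that, on these two cores and in this one test, the swap left the read-out within the scatter, but it does not show how the change would behave on any other core, and since neither step exceeds the scatter, the pair reveals no effect of the change that could be carried over.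

The compounds shown have only methyl or phenyl at this place, so it remains open what an amine, a carboxylic acid or a longer chain there would do. Going by these compounds, all four compounds also carry a hydroxyl group, and what a carbonyl in its stead would do remains open too.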